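Compound 3 to compound 4: methyl for methylamino

A few compounds are considered here, and "the series" means these few. Any claim that something is new, unique, unknown or untested is made for them only; others in the source may bear on it.

Compound 3 `CNc1ncnc2c1c(I)cn2[C@@H]1O[C@H](CO)[C@@H](O)[C@H]1O` has no readable number in a functional assay on HCT-116 cells (Homo sapiens), read by MTT assay, with a stated time of 72 h; a lower number here means a stronger inhibitor, a higher number a weaker inhibitor. In this assay compound 3 gives > 100000 nM, which is a limit.

The change to compound 4 `Cc1ncnc2c1c(I)cn2[C@@H]1O[C@H](CO)[C@@H](O)[C@H]1O` is methyl in place of methylamino on an aromatic carbon.

Compound 1 `Cc1ncnc2c1c(-c1cccs1)cn2[C@@H]1O[C@H](CO)[C@@H](O)[C@H]1O` and compound 2 `C#Cc1cn([C@@H]2O[C@H](CO)[C@@H](O)[C@H]2O)c2ncnc(C)c12` are the nearest guides, since both carry methyl at that place. In this assay compound 1 gives > 20000 nM, which is a limit. Compound 2 gives > 20000 nM, also a limit. Among the compounds with values here, the only measured step is a step that the two limits leave unreadable from compound 1 to compound 2, and it concerns a different group, so no measured step gives a size for this change.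

A shift towards the level of compound 2 at > 20000 nM is therefore the working expectation, with a real chance that only a limit is reported again. The expected move is an at least 4.0-fold lower number from compound 3 to compound 4 (0.60 log units; beyond the scatter), towards stronger inhibition. For compound 4 the estimated value is 25000 nM, with an expected range of 5000 nM to 100000 nM.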

Compound 4, half-maximal inhibitory concentration: 7570 nM
Beside the measured number, compound 4's estimate is 3.3-fold (0.52 log units) above it; the range from low to high includes it.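

In this assay, with iodo held fixed, methyl in place of methylamino on the aromatic carbon gives the first number in this set, and compound 4 shows an at least 13-fold lower number from compound 3 to compound 4 (1.12 log units; beyond the scatter), a size bounded by a limit: the limit of > 100000 nM in this assay, at which 1 of the 4 values shown sits.

With methyl held fixed, the earlier pair gave no readable step, whereas iodo in place of ethynyl gives an at least 2.6-fold lower number from compound 2 to compound 4 (0.42 log units; beyond the scatter), and iodo in place of thiophen-2-yl gives an at least 2.6-fold lower number from compound 1 to compound 4 (0.42 log units; beyond the scatter), both bounded by a limit: the limit of > 20000 nM in this assay, at which 2 of the 4 values shown sit.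

So both the methyl and the iodo of compound 4 go with the gain, though each size is only a bound and the step between compound 1 and compound 2 cannot be read.

Open, on these data alone, is whether ethyl or a primary amine in place of the methyl keeps this gain. Equally open, as far as these compounds go, is whether bromo or chloro can stand in for the iodo.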